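A few compounds are considered here, and "the series" means these few. Any claim that something is new, unique, unknown or untested is made for them only; others in the source may bear on it.

Of the compounds shown here, two share a core and have been tested in a functional assay on K562 cells (Homo sapiens) for inhibition, read by thymidine incorporation, with a stated time of 48 h, tested at 10 ug/mL; a higher number here means more inhibition at the concentration tested (going by the name of the read-out), a lower number less inhibition. Compound 1, `C(#Cc1ncnc2c1ncn2C1CCOCC1)c1ccccc1`, gives 100% in this assay. Going by the values given here, compound 2, `C(#Cc1ncnc2c1ncn2Cc1ccccc1)c1ccccc1`, gives 98% in this assay, and the single measured step, a number 2 percentage points lower from compound 1 to compound 2 (within the scatter), shows that the two numbers sit within the scatter of each other.

Compound 3, `Clc1nc(C#Cc2ccccc2)c2ncn(Cc3ccccc3)c2n1`, differs from compound 2 by one change: chloro in place of hydrogen on an aromatic carbon. Among the compounds with values here, no measured step touches this position on the core; the only step at hand concerns the group on the aromatic nitrogen, and it stayed within the scatter. For compound 3 the number in this assay is expected to stay close to that of compound 2, with a step of a number 3 percentage points lower from compound 2 to compound 3 (within the scatter) that lies within the scatter. Compound 3 is therefore estimated at 95%, with a range from 80% to 100%.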

Compound 3, a percentage reported as inhibition, at one concentration (the size of the read-out at that concentration, not a potency): 100%
Compound 3: the middle estimate sits 5 percentage points below what was measured, within the range that was stated.
By their numbers in this assay, from the lowest: compounds 2, 1 and 3 (each within the scatter of the next).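

Going by these compounds alone, until now, the only measured change was to the group on the aromatic nitrogen; compound 3 gives the first reading at the aromatic carbon between two ring nitrogen atoms, and this assay records a number 2 percentage points higher from compound 2 to compound 3 (within the scatter) for chloro in place of hydrogen there. With a chloro group at this position on the shared core, the number therefore stays level with no shift beyond the scatter, although a reading at one concentration is not a potency and cannot separate compounds with numbers this close. Nothing at hand explains why this change leaves the number so little altered.

As far as these compounds go, it remains open whether an amine or a methoxy group on this carbon would keep the number as high as chloro does. Also open, from the compounds shown here alone, is whether chloro would give the same result with oxan-4-yl on the aromatic nitrogen, the group carried by compound 1.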